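This account rests on a few compounds, and the source may have more. Where it says the series, first, only, none or still open, it means among the compounds named here.

Measured so far: compound 1 `N#Cc1ccc(Nc2cc3[nH]c(-c4cccc(C(F)(F)F)c4)nc3cn2)nc1`, 49%; compound 2 `FC(F)(F)c1ccc(Nc2cc3[nH]c(-c4cccc(C(F)(F)F)c4)nc3cn2)nc1`, 89%.

In an ADME assay on microsomes from liver (Rattus norvegicus) for metabolic stability, read by LC-MS, with a stated time of 30 min, tested at 0.1 uM (on this read-out lower numbers stand for a less stable compound and higher numbers for a more stable compound), compound 2 gives 89%, the higher of the two numbers, while compound 1 gives 49%; the step of a number 40 percentage points higher from compound 1 to compound 2 (beyond the scatter) lies beyond the scatter. Compound 3 `FC1(F)CCC(c2nc3cnc(Nc4ccc(C(F)(F)F)cn4)cc3[nH]2)CC1` differs from compound 2 in one place: 4,4-difluorocyclohexyl in place of 3-(trifluoromethyl)phenyl on an aromatic carbon. Within the data shown here, the single measured step, a number 40 percentage points higher from compound 1 to compound 2 (beyond the scatter), concerns a different part of the shared core, so no measured step bears on this change. With nothing to lean on, a moderate downward step is expected, a number 19 percentage points lower from compound 2 to compound 3 (beyond the scatter), with wide uncertainty. Compound 3 is expected to give 70% in this assay, within 45% to 90%.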

Compound 3, percent of the compound remaining: 89%
For compound 3 the middle estimate is 19 percentage points below the measured one; the measured number falls inside the stated range.
By their numbers in this assay, from the lowest: compound 1; then compounds 2 and 3 (each within the scatter of the next).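

In this assay the group on the aromatic carbon between two ring nitrogen atoms can change from an aromatic ring to a non-aromatic one, with no change at the digits printed from compound 2 to compound 3 (within the scatter) in this swap of 3-(trifluoromethyl)phenyl for 4,4-difluorocyclohexyl. Compound 1 and compound 2 differ elsewhere on the shared core, so they could not show this. Nothing at hand explains why the two groups read alike.

From the compounds shown here alone, whether plain cyclohexyl, with no fluorine, or an amine such as piperidinyl would read the same at this position remains open. Also open, going by these compounds, is whether this swap would read the same with the nitrile of compound 1 in place of trifluoromethyl.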